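The compounds below may be only part of what the source reports. "The series", "measured", "known", "first", "only" and "open" are said of these compounds alone.

In a functional assay on Shh Light II cells (Mus musculus) for inhibition, read by a luciferase reporter (a lower number here means a stronger inhibitor, a higher number a weaker inhibitor), compound 1 `O=C(Nc1ccccc1Cl)N1CCN(c2nc(-c3ccc4ccccc4n3)no2)CC1` gives 140 nM, compound 2 `O=C(Nc1ccccc1Cl)N1CCC(c2nc(-c3ccc4ccccc4n3)no2)CC1` gives 510 nM, and compound 3 `O=C(NC1CCNCC1)N1CCC(c2nc(-c3ccc4ccccc4n3)no2)CC1` gives 2500 nM, the highest of the three numbers. Compound 4 `O=C(N1CCC(c2nc(-c3ccc4ccccc4n3)no2)CC1)N1CCCc2ccccc21` differs from compound 3 in one place: 1,2,3,4-tetrahydroquinolin-1-yl in place of (piperidin-4-yl)amino on a carbonyl carbon. In words, 1,2,3,4-tetrahydroquinolin-1-yl stands in place of (piperidin-4-yl)amino on a carbonyl carbon.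

Among the compounds with values here, one measured step bears on this change: a 4.9-fold higher number from compound 2 to compound 3 (0.69 log units; beyond the scatter), with piperidin-4-yl in place of 2-chlorophenyl on an amide-type nitrogen. That step went from a group with an aromatic name to a non-aromatic ring, and the change to compound 4 brings back one six-membered aromatic ring of carbon only. Within the data shown here, the comparison is loose, since no measured compound carries the incoming group. A move to a lower number, of roughly the size seen from compound 2 to compound 3, therefore seems the likeliest outcome in this assay.

The expected change is a 4.5-fold lower number from compound 3 to compound 4 (0.66 log units; beyond the scatter). For compound 4 the estimated value is 550 nM, with an expected range from 130 nM to 2000 nM.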

Compound 4, half-maximal inhibitory concentration: 2300 nM
Compound 4: middle estimate off by 4.2-fold (0.62 log units), on the low side; measured number outside the range, above it.
By their numbers in this assay, from the lowest: compound 1; then compound 2; then compounds 4 and 3 (each within the scatter of the next).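

In this assay, the change shows a 1.1-fold lower number from compound 3 to compound 4 (0.04 log units; within the scatter), so 1,2,3,4-tetrahydroquinolin-1-yl and (piperidin-4-yl)amino cannot be told apart on this carbonyl carbon. Within the data shown here, with a 4.5-fold higher number from compound 2 to compound 4 (0.65 log units; beyond the scatter), it also becomes clear that having a six-membered aromatic ring of carbon only in the group is not enough here to match (2-chlorophenyl)amino, something the earlier compounds could not show. Nothing available explains this result.

The compounds shown leave open whether the chlorine of (2-chlorophenyl)amino matters, which a plain phenylamino group on the same carbonyl carbon would test. They also leave open how an open-chain amine such as dimethylamino would compare at this place.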